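This account rests on a few compounds, and the source may have more. Where it says the series, first, only, none or still open, it means among the compounds named here.

In a functional assay (lung) for inhibition, with Cavia porcellus as the target (a lower number here means a stronger inhibitor, a higher number a weaker inhibitor), compound 1 `CC(CCC(=O)O)Cc1cccc(OCc2ccc3ccccc3n2)c1` gives 500 nM. Compound 2 `c1ccc2nc(COc3ccc(OCCCc4nnn[nH]4)cc3)ccc2c1` gives 250 nM, which lies within the scatter of the value for compound 1. Among the compounds with values here, compound 3 `O=C(O)CCC(Cc1cccc(OCc2ccc3ccccc3n2)c1)c1ccccc1` gives 56 nM, and it is the only one of the three compounds separated from compound 1 by more than the scatter.

Compound 4 `CC(CCCc1cccc(OCc2ccc3ccccc3n2)c1)C(=O)O` keeps the atoms of compound 1 but joins them differently: 3-carboxybutyl in place of 3-carboxy-1-methylpropyl on a saturated chain carbon bound to an aromatic carbon. Within the data shown here, one measured step bears on this change, and only indirectly. It is an 8.9-fold lower number from compound 1 to compound 3 (0.95 log units; beyond the scatter), which shows that the number can respond to a change in this chain. Among the measured compounds shown here, that step replaces the methyl group with phenyl, however, and no measured pair exchanges these two chains. The size of that step therefore does not carry over, and no step beyond the scatter is expected in this assay.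

The expected result is a 1.1-fold lower number from compound 1 to compound 4 (0.05 log units; within the scatter). For compound 4 the estimated value is 450 nM, with an expected range from 130 nM to 1500 nM.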

Compound 4, half-maximal inhibitory concentration: 75 nM
Compound 4: middle estimate off by 6.0-fold (0.78 log units), on the high side; measured number outside the range, below it.
By their numbers in this assay, from the lowest: compounds 3 and 4 (each within the scatter of the next); then compounds 2 and 1 (each within the scatter of the next).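

Replacing 3-carboxy-1-methylpropyl with 3-carboxybutyl on a saturated chain carbon bound to an aromatic carbon gives a 6.7-fold lower number from compound 1 to compound 4 (0.82 log units; beyond the scatter) in this assay. Within the data shown here, the only earlier step beyond the scatter exchanged methyl for phenyl, whereas here the two chains have the same counts of heavy atoms, double bonds, donors and acceptors, so the number responds to how the same atoms are joined, not only to a change in the atoms present. Nothing measured here accounts for this difference.

The compounds shown leave open whether the methyl group on the 3-carboxybutyl chain contributes at all, as no unbranched chain of that length or ethyl group in its place stands among them. They also leave open whether this chain would keep its number with a tetrazole or an amide in place of the carboxylic acid.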